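A smaller aromatic group on the shared core

The source may report more compounds than this note shows. Statements on the series, on what has been measured and on what is new or still open speak of the compounds shown alone.

Within the data shown here, in a functional assay on MCF7 cells (Homo sapiens) for antiproliferative activity, read by MTT assay, with stated times of 24 h and 72 h (a higher number here means a weaker inhibitor, a lower number a stronger inhibitor), compound 2 (`COc1cc(N2C(=O)[C@@H](Oc3ccccc3)[C@H]2c2cc(N)c(OC)c(O)c2)cc(OC)c1OC`) gives 8800 nM and holds the lower of the two numbers so far, against compound 1 (`COc1cc([C@@H]2[C@H](Oc3ccccc3)C(=O)N2c2cc(OC)c(OC)c(OC)c2)ccc1O`) at 32000 nM on the higher side. Compound 3 (`COc1cc(N2C(=O)[C@@H](Oc3ccccc3)[C@H]2c2cccc(N)c2)cc(OC)c1OC`) alters compound 2 in one place, on a saturated ring carbon, where 3-aminophenyl enters (a group of 7 heavy atoms (6 carbon, 1 nitrogen; one six-membered aromatic ring of carbon only) in place of a group of 10 heavy atoms (7 carbon, 1 nitrogen, 2 oxygen; one six-membered aromatic ring of carbon only), on a saturated ring carbon). Among the measured compounds shown here, the only measured step at that carbon was modest (a 3.6-fold lower number from compound 1 to compound 2 (0.56 log units; beyond the scatter)) and is the sole guide to size. A similarly modest move in this assay is expected, more likely towards a higher number, though this direction is uncertain. The estimated step is expected to be a 1.7-fold higher number from compound 2 to compound 3 (0.23 log units; within the scatter). For compound 3 the estimated value is 15000 nM (range 3500 nM to 50000 nM).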

Compound 3, half-maximal inhibitory concentration: 17000 nM
For compound 3 the middle estimate is 1.1-fold (0.05 log units) below the measured one; the range from low to high includes it.
By their numbers in this assay, from the lowest: compounds 2, 3 and 1 (each within the scatter of the next, the first and the last beyond it).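

At this saturated ring carbon, the smaller 3-aminophenyl group gives a 1.9-fold higher number from compound 2 to compound 3 (0.29 log units; within the scatter) and also a 1.9-fold lower number from compound 1 to compound 3 (0.27 log units; within the scatter) in this assay, so neither step can be told apart from the scatter. Compound 3 therefore sits within the scatter of both neighbours, even though compound 1 and compound 2 lie beyond it from each other. No supporting measurement bears on these numbers.

As far as these compounds go, whether a carboxylic acid or a longer chain in place of the amine of 3-aminophenyl would move the number beyond the scatter remains open.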